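Fluoro in Place of Chloro on the Fused Ring

The compounds below may be only part of what the source reports. "The series", "measured", "known", "first", "only" and "open" are said of these compounds alone.

Compound 3 `CS(=O)(=O)c1ccc(Nc2ncc(F)c(Nc3nc4ccc(Cl)cc4s3)n2)cc1` sits at the far end of the measured set. In a functional assay on HeLa cells (Homo sapiens) for antiproliferative activity, read by MTT assay, with a stated time of 48 h (a lower number here means a stronger inhibitor, a higher number a weaker inhibitor), compound 3 gives > 50000 nM, which is a limit of the assay rather than a number (the limit of > 50000 nM in this assay, at which 1 of the 3 values shown sits). Its nearest measured relative is compound 1 `Cc1ccc2nc(Nc3nc(Nc4ccc(S(C)(=O)=O)cc4)ncc3F)sc2c1`, which differs only by a methyl group where compound 3 carries chloro; compound 1 gives 17200 nM. Going the other way, from methyl to chloro, the change was an at least 2.9-fold higher number from compound 1 to compound 3 (0.46 log units; beyond the scatter). A third compound, compound 2 `CS(=O)(=O)c1ccc(Nc2nccc(Nc3nc4ccc(F)cc4s3)n2)cc1`, shares the fluoro-bearing fused ring that compound 4 will carry but lacks the fluoro on the shared core; compound 2 gives 560 nM.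

Compound 4 `CS(=O)(=O)c1ccc(Nc2ncc(F)c(Nc3nc4ccc(F)cc4s3)n2)cc1` is reached from compound 3 by a single change: fluoro in place of chloro on an aromatic carbon. Among the measured compounds shown here, only one measured step bears directly on this position, the methyl-to-chloro move from compound 1, which cost potency by at least a modest amount. Swapping chloro for the smaller fluoro is expected to pull the number back toward the level of compound 1 rather than further out, so the expected step is an at least 2.5-fold lower number from compound 3 to compound 4 (0.39 log units; beyond the scatter). Compound 4 is therefore estimated at 20000 nM, with a plausible range from 5000 nM to 80000 nM.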

Compound 4, half-maximal inhibitory concentration: > 50000 nM
Compound 4: a limit, no number (the forecaster's own chance of this, stated with the estimate: 30%); middle value at least 2.5-fold (0.39 log units) from the limit.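

Compound 4 sits at the same limit of the assay as compound 3, so the swap of chloro for fluoro on the fused ring cannot be read in either direction, and the same holds for any ranking of the two halogens: the limit of > 50000 nM in this assay, at which 2 of the 4 values shown sit.

The clearest new information comes from the shared core, where adding a fluoro gives an at least 89-fold higher number from compound 2 to compound 4 (1.95 log units; beyond the scatter). Compound 2 and compound 4 carry the same fluoro on the fused ring, so in this pair the large loss in this assay goes with the fluoro on the core alone. Fluoro in place of methyl on the fused ring gives an at least 2.9-fold higher number from compound 1 to compound 4 (0.46 log units; beyond the scatter), which means that with the core fluoro present, methyl is the only group shown at this carbon that keeps a measurable value.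

On these data alone, how far compound 3 and compound 4 lie past the limit remains unknown, as does whether removing the core fluoro would bring a similar gain with chloro or methyl on the fused ring. As far as these compounds go, how a methoxy group or an amine would behave at this carbon of the fused ring also remains open.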